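Swapping the amide group on compound 3

A few compounds are considered here, and "the series" means these few. Any claim that something is new, unique, unknown or untested is made for them only; others in the source may bear on it.

Measured in a physicochemical assay for solubility, read by spectrophotometry, measured as kinetic solubility, at pH 8, tested at 500 uM; a lower number here means a less soluble compound, a higher number a more soluble compound:
- compound 1 (`CNC(=O)c1ccncc1Nc1cc(-c2ccc3ccn(C)c3c2)c2nccnc2c1`): 4 ug/mL
- compound 2 (`Cn1ccc2ccc(-c3cc(Nc4cnccc4C(=O)NC4CCNC(=O)C4)cc4nccnc34)cc21`): 242 ug/mL
- compound 3 (`CN1CC(NC(=O)c2ccncc2Nc2cc(-c3ccc4ccn(C)c4c3)c3nccnc3c2)C1`): 170 ug/mL

Two of these three numbers sit high, and compound 3 holds one of them. Its gap to the other is a 1.4-fold lower number from compound 2 to compound 3 (0.15 log units; within the scatter), while the climb from the low number is a 43-fold higher number from compound 1 to compound 3 (1.63 log units; beyond the scatter).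

Compound 4 (`CN1CCC(N(C)C(=O)c2ccncc2Nc2cc(-c3ccc4ccn(C)c4c3)c3nccnc3c2)C1`) is still unmeasured. Its difference is methyl(1-methylpyrrolidin-3-yl)amino in place of (1-methylazetidin-3-yl)amino on a carbonyl carbon.

The large steps, this one and a 61-fold higher number from compound 1 to compound 2 (1.78 log units; beyond the scatter), both start from methyl on an amide-type nitrogen, so they bear on this change only loosely. The closer guide is the exchange of one ring group for another, which gave only a 1.4-fold lower number from compound 2 to compound 3 (0.15 log units; within the scatter). For the measured compounds named here, no measured compound lacks the amide hydrogen, so that part of the change is untested, and the range stays wide. The expected result is therefore no step beyond the scatter, estimated as no change at the digits printed from compound 3 to compound 4 (within the scatter). For compound 4 the estimated value is 170 ug/mL, with an expected range from 75 ug/mL to 260 ug/mL.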

Compound 4, solubility: 245 ug/mL
Compound 4: middle estimate off by 1.4-fold (0.16 log units), on the low side; the range from low to high includes it.
By their numbers in this assay, from the lowest: compound 1; then compounds 3, 2 and 4 (each within the scatter of the next).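

In this assay, compound 4 carries no amide hydrogen and has a five-membered ring in place of a four-membered one, yet the result is a 1.4-fold higher number from compound 3 to compound 4 (0.16 log units; within the scatter) and a 1.0-fold higher number from compound 2 to compound 4 (0.01 log units; within the scatter). So a high number at this position does not depend on the amide hydrogen, and it is not tied to one ring group: the result is also a 61-fold higher number from compound 1 to compound 4 (1.79 log units; beyond the scatter), and compounds 2, 3 and 4 all stand well clear of compound 1, with none of the four going against this. No measurement shown here gives a reason for these results.

Compound 4 changes the ring and the amide nitrogen together, so the share of each remains unseparated. Also open, going by these compounds, is how an open-chain amine, such as 2-(dimethylamino)ethyl on the amide nitrogen, would read.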